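A single swap on a carbonyl carbon

A few compounds are considered here, and "the series" means these few. Any claim that something is new, unique, unknown or untested is made for them only; others in the source may bear on it.

Compound 1 `CC(C)C(=O)N1C[C@@H](O[C@H](C)c2cc(C(F)(F)F)cc(C(F)(F)F)c2)[C@H](c2ccc(F)cc2)C1` gives 0.15 nM in an assay on CHO cells for displacement of a labelled ligand from Substance-P receptor (Homo sapiens); on this read-out higher numbers stand for weaker inhibition and lower numbers for stronger inhibition.
Compound 2 `C[C@@H](O[C@@H]1CN(C(=O)[C@@H]2COC(=O)N2)C[C@H]1c1ccc(F)cc1)c1cc(C(F)(F)F)cc(C(F)(F)F)c1` gives 0.34 nM in this assay.
Compound 3 `C[C@@H](O[C@@H]1CN(C(=O)N(C)C)C[C@H]1c1ccc(F)cc1)c1cc(C(F)(F)F)cc(C(F)(F)F)c1` gives 0.38 nM in this assay.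

Compound 3 has the highest number of the three: the step of a 1.1-fold higher number from compound 2 to compound 3 (0.05 log units; within the scatter) lies within the scatter, whereas a 2.5-fold higher number from compound 1 to compound 3 (0.40 log units; beyond the scatter) lies beyond it.

Compound 4 `CCNC(=O)N1C[C@@H](O[C@H](C)c2cc(C(F)(F)F)cc(C(F)(F)F)c2)[C@H](c2ccc(F)cc2)C1` differs from compound 3 by ethylamino in place of dimethylamino on a carbonyl carbon. Going by the values given here, no measured step covers this particular exchange. The two measured changes at the same carbonyl carbon, a 2.3-fold higher number from compound 1 to compound 2 (0.36 log units; beyond the scatter) and a 2.5-fold higher number from compound 1 to compound 3 (0.40 log units; beyond the scatter), were both modest, so for this assay only a small step is expected, in either direction, quite possibly none beyond the scatter. Compound 4 is therefore estimated at 0.4 nM, with a range from 0.15 nM to 1.2 nM, which is expected to be a step of a 1.1-fold higher number from compound 3 to compound 4 (0.02 log units; within the scatter).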

Compound 4, half-maximal inhibitory concentration: 0.1 nM
Beside the measured number, compound 4's estimate is 4.0-fold (0.60 log units) above it; the whole stated range lies above it.
By their numbers in this assay, from the lowest: compounds 4 and 1 (each within the scatter of the next); then compounds 2 and 3 (each within the scatter of the next).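

Swapping dimethylamino for ethylamino on this carbonyl carbon keeps the same heavy atoms and adds one hydrogen-bond donor, yet it gives a 3.8-fold lower number from compound 3 to compound 4 (0.58 log units; beyond the scatter) in this assay, so rearranging these atoms alone can shift the number beyond the scatter. Ethylamino also gives a 3.4-fold lower number from compound 2 to compound 4 (0.53 log units; beyond the scatter), whereas a 1.5-fold lower number from compound 1 to compound 4 (0.18 log units; within the scatter) stays within the scatter, which places ethylamino level with isopropyl at this position. Nothing available explains these steps.

The compounds shown leave open whether the amide hydrogen or the ethyl chain goes with the lower number. From the compounds shown here alone, how a methylamino group or a longer propylamino chain would read on this carbonyl carbon also remains open.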